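Ethoxy in place of methyl: what compound 4 should show

The source may report more compounds than this note shows. Statements on the series, on what has been measured and on what is new or still open speak of the compounds shown alone.

Compound 1 `Cc1ccc(NCN2C(=O)c3ccccc3C2=O)cc1` stands highest of the three numbers in an assay on isolated protein for inhibition of ribosomal protein S6 kinase alpha-2 (Homo sapiens), read by fluorescence, with a stated time of 20 min (a higher number here means a weaker inhibitor, a lower number a stronger inhibitor), where compound 1 gives 4300 nM. Compound 2 `COc1ccc(NCN2C(=O)c3ccccc3C2=O)cc1` gives 470 nM and compound 3 `O=C1c2ccccc2C(=O)N1CNc1ccc(O)cc1` gives 520 nM. Compound 4 `CCOc1ccc(NCN2C(=O)c3ccccc3C2=O)cc1` differs from compound 1 in one place: ethoxy in place of methyl on an aromatic carbon. Among the compounds with values here, two measured steps bear on this change. Methoxy in place of methyl gave a 9.1-fold lower number from compound 1 to compound 2 (0.96 log units; beyond the scatter), and hydroxy in place of methyl gave an 8.3-fold lower number from compound 1 to compound 3 (0.92 log units; beyond the scatter); between those two products the numbers lie close, a 1.1-fold higher number from compound 2 to compound 3 (0.04 log units; within the scatter). Both replacements lowered the number well beyond the scatter, and the ethoxy group is expected to behave alike, so the estimated step is a 7.2-fold lower number from compound 1 to compound 4 (0.86 log units; beyond the scatter). Compound 4 is therefore expected to give 600 nM in this assay, with a likely range from 250 nM to 2000 nM.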

Compound 4, half-maximal inhibitory concentration: 590 nM
The estimate for compound 4 lay 1.0-fold (0.01 log units) above the measured number; measured number inside the range.
By their numbers in this assay, from the lowest: compounds 2, 3 and 4 (each within the scatter of the next); then compound 1.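

With ethoxy on this aromatic carbon, para to a large group, the lower number seen with methoxy and hydroxy persists, giving a 7.3-fold lower number from compound 1 to compound 4 (0.86 log units; beyond the scatter) and showing that a larger group on the oxygen is tolerated here. Ethyl in place of the hydroxy hydrogen gives a 1.1-fold higher number from compound 3 to compound 4 (0.05 log units; within the scatter) and the added methyl on the methoxy group gives a 1.3-fold higher number from compound 2 to compound 4 (0.10 log units; within the scatter) so hydroxy, methoxy and ethoxy stay within the scatter of one another. Nothing shown gives a reason for this.

Going by these compounds, whether a longer chain such as butoxy on that oxygen keeps the number this low remains open, as does whether an amine or a chlorine atom in place of the methyl would match the oxygen-linked groups.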